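The source may report more compounds than this note shows. Statements on the series, on what has been measured and on what is new or still open speak of the compounds shown alone.

Compound 1, with the structure `COc1c(C)cnc(CN2CC(=O)N(C)c3c(Cl)nc(N)nc32)c1C`, is the weaker of the two measured compounds: in a functional assay on HT-29 cells (Homo sapiens) for inhibition (a lower number here means a stronger inhibitor, a higher number a weaker inhibitor), compound 1 gives 1470 nM, the highest of the two numbers. Going by the values given here, compound 2, with the structure `COc1ccnc(CN2CC(=O)N(CC(C)C)c3c(Cl)nc(N)nc32)c1OC`, gives 40 nM in this assay, a much lower number; the two compounds differ in more than one place, so the reading says only that the pair spans a wide range. Compound 3, with the structure `COc1c(C)cnc(CN2CC(=O)N(C(C)C(=O)NCCN(C)C)c3c(Cl)nc(N)nc32)c1C`, has not yet been measured. It is reached from compound 1 by a single change: 1-((2-(dimethylamino)ethyl)carbamoyl)ethyl in place of methyl on an amide-type nitrogen in a ring. Among the compounds with values here, no pair of measured compounds shows this change alone, so its effect on the number is unknown here. The expectation for compound 3 is a moderate move to a lower number in this assay, given as the step of a 2.5-fold lower number from compound 1 to compound 3 (0.39 log units; beyond the scatter). Compound 3 is thus estimated at 600 nM, within a range from 150 nM to 2500 nM.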

Compound 3, half-maximal inhibitory concentration: 100 nM
The estimate for compound 3 lay 6.0-fold (0.78 log units) above the measured number; measured number outside the range, below it.
By their numbers in this assay, from the lowest: compound 2; then compound 3; then compound 1.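

At the amide-type nitrogen in a ring, a group far larger than methyl is compatible with stronger inhibition: in this assay, 1-((2-(dimethylamino)ethyl)carbamoyl)ethyl in place of methyl gives a 15-fold lower number from compound 1 to compound 3 (1.17 log units; beyond the scatter). The larger group adds a chain, a hydrogen-bond donor and hydrogen-bond acceptors, yet the number falls rather than rises. No measurement shown gives a reason for this step.

This single step changes several features at once, so it leaves open which part of the new group goes with the lower number. Comparing compound 1 and compound 3 with analogues carrying an ethyl group, a carboxylic acid or a simple primary amide at this nitrogen would help separate the contributions of the branch, the amide and the terminal dimethylamine.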